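Naphthyl for formylphenyl on the benzyl core

This account rests on a few compounds, and the source may have more. Where it says the series, first, only, none or still open, it means among the compounds named here.

Compound 1 `O=Cc1ccc(-c2cn3ccnc3c(-c3ccc4ncn(C5CCCCC5)c4c3)n2)cc1` is the reference of the series. In a functional assay on SF-268 cells (Homo sapiens) for inhibition, read by sulforhodamine B assay, with a stated time of 48 h, tested at 10 uM (on this read-out higher numbers stand for more inhibition at the one concentration tested (going by the name of the read-out) and lower numbers for less inhibition), compound 1 gives 27.1%. Compound 2 `c1ccc2c(-c3cn4ccnc4c(-c4ccc5ncn(C6CCCCC6)c5c4)n3)cccc2c1` carries the change (naphthalen-1-yl in place of 4-formylphenyl on an aromatic carbon), and in this assay compound 2 gives 7.84%; the step is a number 19.3 percentage points lower from compound 1 to compound 2 (beyond the scatter). Compound 3 `O=Cc1ccc(-c2cn3ccnc3c(-c3ccc4ncn(Cc5ccccc5)c4c3)n2)cc1` differs from compound 1 by benzyl in place of cyclohexyl on an aromatic nitrogen, and in this assay compound 3 gives 27.1%, with the step of no change at the digits printed from compound 1 to compound 3 (within the scatter). Compound 3 thus stands level with compound 1 at the digits given, and the two together hold the highest numbers of the three measured, while compound 2 is the furthest from compound 3.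

Compound 4 `c1ccc(Cn2cnc3ccc(-c4nc(-c5cccc6ccccc56)cn5ccnc45)cc32)cc1` has not been measured in this assay. It differs from compound 3 by naphthalen-1-yl in place of 4-formylphenyl on an aromatic carbon. Among the compounds with values here, this is the same change as the one from compound 1 to compound 2, made on the core of compound 3 instead of the core of compound 1; the surroundings of the place are described in identical words for both pairs, so the change is the same. The difference between the two cores is benzyl in place of cyclohexyl on an aromatic nitrogen. Among the compounds shown the change occurs twice in all.

Within the data shown here, for compound 4 the step is expected to be about a number 19.1 percentage points lower from compound 3 to compound 4 (beyond the scatter), resting on the only measured instance, the step of a number 19.3 percentage points lower from compound 1 to compound 2 (beyond the scatter). Among the measured compounds shown here, only one instance is available, so the expectation is loose. Compound 4 is estimated at 8% in this assay, with a range from 0% to 20%.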

Compound 4, a percentage reported as inhibition, at one concentration (the size of the read-out at that concentration, not a potency): 10.3%
The estimate for compound 4 lay 2.3 percentage points below the measured number; measured number inside the range.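

In this assay the exchange of 4-formylphenyl for naphthalen-1-yl carries over from the core of compound 1 to the core of compound 3, with a number 16.8 percentage points lower from compound 3 to compound 4 (beyond the scatter) matching the earlier step: the same change on two cores in this assay, a number 19.3 percentage points lower (beyond the scatter) from compound 1 to compound 2 and a number 16.8 percentage points lower (beyond the scatter) from compound 3 to compound 4, 2.5 percentage points apart, within the scatter of two such steps

Benzyl in place of cyclohexyl on the aromatic nitrogen leaves no readable step on either aryl partner, a number 2.5 percentage points higher from compound 2 to compound 4 (within the scatter) being the step on the naphthalen-1-yl side, so the two changes read as independent within these four compounds: the same change on two cores in this assay, no change at the digits printed (within the scatter) from compound 1 to compound 3 and a number 2.5 percentage points higher (within the scatter) from compound 2 to compound 4, 2.5 percentage points apart, within the scatter of two such steps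

This rests on a single pair of cores and a single read-out at one concentration, so it shows neither that the step would hold on other cores nor why the number falls, and it says nothing about potency.

The compounds shown leave open whether the lower number goes with losing the formyl group or with gaining the second aromatic ring, a separation that a plain phenyl, or a phenyl bearing an amine or a carboxylic acid, at the same place could make. On these data alone, on the aromatic nitrogen only cyclohexyl and benzyl appear, so it also stays open whether a longer alkyl chain or an amine-bearing chain there would leave the step as it stands.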